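The compounds below may be only part of what the source reports. "The series", "measured", "known", "first", "only" and "open" are said of these compounds alone.

Measured so far:
compound 1 `CSc1ccc(N(C)c2ncnc3occ(C)c23)cc1`: 18.6 nM
compound 2 `CCN(c1ccc(OC)cc1)c1ncnc2occ(C)c12`: 14.5 nM
compound 3 `CCc1ccc(N(C)c2ncnc3occ(C)c23)cc1`: 156 nM

In a functional assay on SK-OV-3 cells (Homo sapiens) for inhibition, read by sulforhodamine B assay, with a stated time of 48 h (a higher number here means a weaker inhibitor, a lower number a stronger inhibitor), compound 3 gives 156 nM, the highest number of the three. The next compound, compound 4 `COc1ccc(N(C)c2ncnc3occ(C)c23)cc1`, has not yet been measured. It replaces the ethyl of compound 3 with methoxy on an aromatic carbon: methoxy in place of ethyl on an aromatic carbon.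

Among the compounds with values here, one measured step touches the same aromatic carbon: an 8.4-fold higher number from compound 1 to compound 3 (0.92 log units; beyond the scatter), where ethyl took the place of methylsulfanyl. That step was beyond the scatter, and it shows ethyl as the group with the higher number in that single pair. Compound 2 also carries methoxy on its aromatic ring, although it differs from compound 4 elsewhere, and compound 2 gives 14.5 nM. That value lies within the scatter of compound 1 at 18.6 nM. Within the data shown here, no measured pair exchanges ethyl for methoxy directly, so this is an inference from neighbouring compounds. Among the measured compounds shown here, a drop of similar size to the one seen between compound 1 and compound 3 is therefore expected in this assay, towards a lower number.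

The estimated step is a 7.8-fold lower number from compound 3 to compound 4 (0.89 log units; beyond the scatter). For compound 4 the expected value is about 20 nM, with an estimated range from 7 nM to 60 nM.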

Compound 4, half-maximal inhibitory concentration: 7.7 nM
Beside the measured number, compound 4's estimate is 2.6-fold (0.41 log units) above it, within the range that was stated.
By their numbers in this assay, from the lowest: compounds 4, 2 and 1 (each within the scatter of the next, the first and the last beyond it); then compound 3.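

In this assay, within the data shown here, the direct exchange on this aromatic carbon, para to a large group, gives a 20-fold lower number from compound 3 to compound 4 (1.31 log units; beyond the scatter) in the first measured pair of methoxy and ethyl, and the two groups have the same number of heavy atoms, with methoxy holding an oxygen where ethyl holds a carbon. Methoxy can also now be set against methylsulfanyl at the same place, where a 2.4-fold lower number from compound 1 to compound 4 (0.38 log units; beyond the scatter) is a much smaller step, so among the three groups shown here ethyl stands well apart, with the highest number, while methoxy gives the lowest. The remaining change, hydrogen in place of methyl on a saturated chain carbon bound to a nitrogen on an aromatic ring, gives a 1.9-fold lower number from compound 2 to compound 4 (0.27 log units; within the scatter) and so shows no difference beyond the scatter in this one pair.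

No evidence is available to account for the large gap between ethyl and the two groups that carry a heteroatom. From the compounds shown here alone, it also remains open whether a hydroxyl, an amine, a chlorine or a longer chain such as propoxy on this aromatic carbon would stay as low as methoxy or rise towards ethyl.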